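This account rests on a few compounds, and the source may have more. Where it says the series, first, only, none or still open, it means among the compounds named here.

Compound 2 `Fc1ccc(-c2nc3sc(Cc4ccc(Cl)cc4)nn3c2Br)cc1` stands in an ADME assay on CCRF-CEM cells (Homo sapiens) for cytotoxicity, with a stated time of 72 h (a lower number here means a stronger inhibitor, a higher number a weaker inhibitor), only at a limit, > 250000 nM. Compound 1 `Fc1ccc(-c2cn3nc(Cc4ccc(Cl)cc4)sc3n2)cc1` likewise reaches only a limit in this assay, > 250000 nM. The step from compound 1 to compound 2 is therefore a step that the two limits leave unreadable from compound 1 to compound 2, and what the two numbers show is the limit of > 250000 nM in this assay, at which 2 of the 2 values shown sit. Compound 3 `COc1ccc(-c2nc3sc(Cc4ccc(Cl)cc4)nn3c2Br)cc1` differs from compound 2 by methoxy in place of fluoro on an aromatic carbon. Among the compounds with values here, no measured step speaks to this change, so compound 3 is expected to stay close to its starting point, with a step that the limit leaves unreadable from compound 2 to compound 3. Compound 3 is thus estimated at 300000 nM, between 100000 nM and 1000000 nM, and will most probably again be reported only as a limit.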

Compound 3, half-maximal inhibitory concentration: 58000 nM
Beside the measured number, compound 3's estimate is 5.2-fold (0.71 log units) above it; the whole stated range lies above it.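

Methoxy in place of fluoro on this six-membered aromatic ring matters: in this assay the change gives an at least 4.3-fold lower number from compound 2 to compound 3 (0.63 log units; beyond the scatter), and compound 3 is the only one of the three with a readable number. This position can therefore move the read-out, which compounds 1 and 2 could not show. On these data alone, the true size of the step stays open, because compound 2 stands only at a limit: the limit of > 250000 nM in this assay, at which 2 of the 3 values shown sit. As far as these compounds go, whether an amine or an ethoxy chain here would lower the number further remains open. So does whether methoxy would act alike on compound 1, which lacks the bromo.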